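Nitro for Methoxy on a Compound Already at the Limit

The source may report more compounds than this note shows. Statements on the series, on what has been measured and on what is new or still open speak of the compounds shown alone.

Compound 1 `COc1ccc(CN(C)c2nc(Cc3c(Cl)cccc3Cl)c(C)c(=O)[nH]2)cc1` and compound 2 `Cc1c(Cc2c(Cl)cccc2Cl)nc(N(C)Cc2ccc([N+](=O)[O-])cc2)[nH]c1=O` share one core and differ by nitro in place of methoxy on an aromatic carbon. In an ADME assay on TZM cells (Homo sapiens) for cytotoxicity, read by WST assay, with a stated time of 2 days (a higher number here means that more compound is tolerated, a lower number that less compound is tolerated), compound 1 gives 17900 nM. In this assay compound 2 gives 19500 nM. The step between them is a 1.1-fold higher number from compound 1 to compound 2 (0.04 log units; within the scatter).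

Compound 3 `COc1ccc(CN(C)c2nc(C(C)c3c(Cl)cccc3Cl)c(C)c(=O)[nH]2)cc1` differs from compound 1 by methyl in place of hydrogen on a saturated chain carbon bound to two aromatic carbons. In this assay compound 3 reaches only a limit of the assay, > 100000 nM; this is the limit of > 100000 nM in this assay, at which 1 of the 3 values shown sits. The step is an at least 5.5-fold higher number from compound 1 to compound 3 (0.74 log units; beyond the scatter).

Compound 4 `Cc1c(C(C)c2c(Cl)cccc2Cl)nc(N(C)Cc2ccc([N+](=O)[O-])cc2)[nH]c1=O` is not yet measured. It differs from compound 3 by nitro in place of methoxy on an aromatic carbon, the same change that turns compound 1 into compound 2, made on a core that differs from theirs by the methyl described above. For compound 4 the expected step of a number no higher from compound 3 to compound 4 (the limit leaves the size open) is small, because a 1.1-fold higher number from compound 1 to compound 2 (0.04 log units; within the scatter) stayed within the scatter. Compound 4 is therefore estimated at 100000 nM, with a range from 45000 nM to 220000 nM, and a result that is again only a limit seems likely.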

Compound 4, half-maximal cytotoxic concentration: > 50000 nM
Compound 4: a limit, no number (the forecaster's own chance of this, stated with the estimate: 70%); the middle value is on the limit's open side.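

Compound 4 reaches only a limit of the assay in this assay, > 50000 nM, and not a number. The methyl in place of hydrogen on the saturated chain carbon carries over to the nitro compounds, with an at least 2.5-fold higher number from compound 2 to compound 4 (0.40 log units; beyond the scatter), and it raises the number on both cores, though its size cannot be compared: the same change on two cores in this assay, an at least 5.5-fold higher number (0.74 log units; beyond the scatter) from compound 1 to compound 3 and an at least 2.5-fold higher number (0.40 log units; beyond the scatter) from compound 2 to compound 4; the limit leaves it open whether they differ. Nitro in place of methoxy gave a 1.1-fold higher number from compound 1 to compound 2 (0.04 log units; within the scatter), but the step between compound 3 and compound 4 cannot be read, so the data do not show whether this change stays as small on the core that carries the methyl.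

On these data alone, with both methyl compounds at limits, the true size of the methyl step on each core remains open. Also open, as far as these compounds go, is how an ethyl in place of that methyl, or an amine or a carboxylic acid in place of the methoxy or nitro, would behave in this assay.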